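The source may report more compounds than this note shows. Statements on the series, on what has been measured and on what is new or still open speak of the compounds shown alone.

Measured so far in an ADME assay on L929 cells (Mus musculus) for cytotoxicity, read by resazurin assay, with a stated time of 48 h; a higher number here means that more compound is tolerated, a lower number that less compound is tolerated:
- compound 1 (`C#CCn1c2ccc([N+](=O)[O-])cc2c(=O)n1Cc1ccccc1`) gives 195000 nM
- compound 2 (`COC(=O)Cn1c2ccc([N+](=O)[O-])cc2c(=O)n1Cc1ccccc1`) gives 129000 nM

Compound 2 stands within the scatter of compound 1, so these two values set no order. The next structure is compound 3 (`N#CCn1c2ccc([N+](=O)[O-])cc2c(=O)n1Cc1ccccc1`), with cyano in place of methoxycarbonyl on a saturated chain carbon bound to an aromatic nitrogen. Among the compounds with values here, one measured step bears on this change, at the same place (a 1.5-fold lower number from compound 1 to compound 2 (0.18 log units; within the scatter)), and it stayed within the scatter. On that single step, no change beyond the scatter is expected in this assay and neither direction is favoured. The expected step is small (a 1.1-fold higher number from compound 2 to compound 3 (0.04 log units; within the scatter)). For compound 3 the estimated value is 140000 nM with an expected range from 65000 nM to 280000 nM as the working span.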

Compound 3, concentration lethal to 50% of the cells: > 256000 nM
Compound 3 ended at the assay's limit; the forecaster's own chance of this, stated with the estimate: 10%; at least 1.8-fold (0.26 log units) between middle value and limit.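

In this assay compound 3 gives > 256000 nM, which is a limit of the assay and not a number. Cyano on a saturated chain carbon bound to an aromatic nitrogen thus brings the first open-ended reading at this position, with an at least 1.9-fold higher number from compound 2 to compound 3 (0.29 log units; that floor lies within the scatter) and an at least 1.3-fold higher number from compound 1 to compound 3 (0.11 log units; that floor lies within the scatter). Both steps are floors only, so no order among the three compounds can be set, and the exchange of methoxycarbonyl for cyano, with its smaller count of heavy atoms, shows no step beyond the scatter, though one remains possible.

On these data alone, how far the true value of compound 3 lies from its limit stays open. Also open, as far as these compounds go, is whether a carboxylic acid, an amine or a longer chain at this place would give a step beyond the scatter.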